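The compounds below may be only part of what the source reports. "The series", "measured", "known", "first", "only" and "open" are said of these compounds alone.

Measured compounds:
compound 1 `Cc1ccc(-c2nc(=O)o[nH]2)c(-c2ccc([C@@H](C)N(CC3CC3)c3nc4c(C(=O)O)cccc4o3)cc2)c1`: 0.00023
compound 2 `CCCCN(c1nc2c(NC(C)=O)cccc2o1)[C@H](C)c1ccc(-c2ccccc2-c2nnn[nH]2)cc1`: 0.00102
compound 3 `C[C@H](c1ccc(-c2cc(F)ccc2-c2nc(=O)o[nH]2)cc1)N(CC1CC1)c1nc2c(C(=O)O)cccc2o1`: 0.0000977

In an ADME assay on the whole organism (plasma, Macaca fascicularis) for protein binding, read by LC-MS, using equilibrium dialysis and cassette dosing, with a stated time of 24 h, at a dose of 1 mg/kg by the oral route (on this read-out higher numbers stand for a larger free fraction and lower numbers for a smaller free fraction), compound 2 gives the highest of the three numbers. Compound 1 gives 0.00023 and compound 3 gives 0.0000977, and the gap from compound 2 to each of them lies beyond the scatter.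

The unmeasured compound 4 `CCCCN(c1nc2c(NS(C)(=O)=O)cccc2o1)[C@H](C)c1ccc(-c2ccccc2-c2nnn[nH]2)cc1` is reached from compound 2 by a single change:
methylsulfonyl in place of acetyl on a nitrogen on an aromatic ring
Cut one bond further out, the change reads acetamido to methanesulfonamido.

For the measured compounds named here, only one measured step is available, a 2.4-fold lower number from compound 1 to compound 3 (0.37 log units; beyond the scatter), and it concerns fluoro in place of methyl on an aromatic carbon in the pair carrying a carboxylic acid, not the nitrogen on the aromatic ring of compound 2. It therefore does not bear on the present change. Going by the values given here, no measured pair replaces acetyl by methylsulfonyl, so the expectation for compound 4 rests on the value of compound 2 alone.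

Compound 4 is expected to give a number in this assay that differs from compound 2 by no more than the scatter, a step of a 1.0-fold lower number from compound 2 to compound 4 (0.01 log units; within the scatter).

The estimate for compound 4 is 0.001, with a range from 0.0004 to 0.0025.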

Compound 4, unbound fraction: 0.000203
Compound 4: the middle estimate sits 4.9-fold (0.69 log units) above what was measured; the measured number lies below the stated range.
By their numbers in this assay, from the lowest: compound 3; then compounds 4 and 1 (each within the scatter of the next); then compound 2.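

In this assay, methylsulfonyl in place of acetyl on a nitrogen on an aromatic ring gives a 5.0-fold lower number from compound 2 to compound 4 (0.70 log units; beyond the scatter), so the change from acetamido to methanesulfonamido moves the unbound fraction by more than repeated measurements would. For the compounds shown here, the earlier compounds offered no measured step at this position: their only step, a 2.4-fold lower number from compound 1 to compound 3 (0.37 log units; beyond the scatter), concerns fluoro in place of methyl on an aromatic carbon elsewhere in the structure, and the new pair therefore shows for the first time that this nitrogen substituent is not silent in this read-out. Nothing measured here accounts for the drop in the free fraction, which stands as an observation from one pair.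

A single pair cannot show whether the drop belongs to the methylsulfonyl group itself or would also appear with another group on this nitrogen, such as ethylsulfonyl, a urea or the bare amine. It also leaves open whether the same exchange gives a step of similar size when the butyl chain on the other nitrogen is replaced by cyclopropylmethyl.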